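Moving One Methyl Group: From Compound 1 to Compound 4

This account rests on a few compounds, and the source may have more. Where it says the series, first, only, none or still open, it means among the compounds named here.

Measured so far:
compound 1 `Cc1ccc(N2CCN(CCC(OC(N)=O)c3ccccc3)CC2)c(C)c1`: 34%
compound 2 `COc1ccc(N2CCN(CCC(OC(N)=O)c3ccc(C)c(C)c3)CC2)cc1`: 58%
compound 3 `COc1ccc(N2CCN(CCC(OC(N)=O)c3ccc(Cl)cc3Cl)CC2)cc1`: 16%

In a functional assay on the whole organism for inhibition, with Mus musculus as the target, in the writhing test, with a stated time of 1 h, at a dose of 10 mg/kg by the oral route (a lower number here means less inhibition, a higher number more inhibition at the dose given (going by the name of the read-out)), compound 1 gives 34%, the second highest of the three numbers; compound 3 stands lower and compound 2 higher, each beyond the scatter. Compound 4 `Cc1cccc(C)c1N1CCN(CCC(OC(N)=O)c2ccccc2)CC1` has the same atoms joined differently: 2,6-dimethylphenyl in place of 2,4-dimethylphenyl on an amine nitrogen in a ring. Among the measured compounds shown here, the only measured step, a number 42 percentage points lower from compound 2 to compound 3 (beyond the scatter), concerns the other phenyl ring, the one on the saturated chain carbon bound to an oxygen next to a carbonyl group, so it does not bear on this change. Compounds 1 and 2 differ at both rings, so their two values cannot separate the effects. With no direct guide, a step of a number 1 percentage points higher from compound 1 to compound 4 (within the scatter) is expected, within the scatter. Compound 4 is estimated at 35%, between 15% and 55%.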

Compound 4, a percentage reported as inhibition, in the whole organism at one dose (the size of the read-out at that dose, not a potency): 48%
Compound 4: middle estimate off by 13 percentage points, on the low side; measured number inside the range.
By their numbers in this assay, from the lowest: compound 3; then compound 1; then compounds 4 and 2 (each within the scatter of the next).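

Moving one methyl group, with 2,6-dimethylphenyl in place of 2,4-dimethylphenyl, gives a number 14 percentage points higher from compound 1 to compound 4 (beyond the scatter) in this assay. Among the compounds shown here, the earlier compounds could not show this: only this step isolates the ring on the amine nitrogen, and it shows that the arrangement of the same atoms there can change the read-out. No measurement available explains this difference.

Still open, going by these compounds, is whether ethyl groups or an amine in place of these methyl groups would give a similar number, and whether 2,6-dimethylphenyl would act alike alongside the other phenyl rings of compound 2 and compound 3.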